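The compounds below may be only part of what the source reports. "The series", "measured", "known", "first", "only" and "open" are said of these compounds alone.

In a functional assay, with a stated time of 10 min (a higher number here means a weaker inhibitor, a lower number a stronger inhibitor), compound 3 `Cn1cc(O)c(=O)cc1/C=C/c1ccc(Cl)cc1` gives 5720 nM. Compound 1 `CN(C)c1ccc(/C=C/c2cc(=O)c(O)c[nH]2)cc1` gives 3410 nM. Compound 2 `Cn1cc(O)c(=O)cc1/C=C/c1ccccc1` gives 2110 nM. The gap between compound 3 and compound 1 lies within the scatter, whereas the gap between compound 3 and compound 2 is larger than the scatter. The next structure, compound 4 `CN(C)c1ccc(/C=C/c2cc(=O)c(O)cn2C)cc1`, has dimethylamino in place of chloro on an aromatic carbon of compound 3: dimethylamino in place of chloro on an aromatic carbon.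

Among the compounds with values here, only one measured step falls at this place: a 2.7-fold higher number from compound 2 to compound 3 (0.43 log units; beyond the scatter), modest and beyond the scatter, for chloro in place of hydrogen. No exchange of chloro for dimethylamino has been measured on any core. Compound 1 carries dimethylamino on a different core and gives 3410 nM, so it offers only indirect support. In this assay, a move towards a lower number is expected, no larger than the modest step seen with chloro, and it may not clear the scatter. The expected change is a 1.8-fold lower number from compound 3 to compound 4 (0.25 log units; within the scatter). Compound 4 is estimated at 3200 nM, with an expected range of 1300 nM to 7500 nM.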

Compound 4, half-maximal inhibitory concentration: 2520 nM
For compound 4 the middle estimate is 1.3-fold (0.10 log units) above the measured one; low and high end bracket the measured number.
By their numbers in this assay, from the lowest: compounds 2, 4, 1 and 3 (each within the scatter of the next, the first and the last beyond it).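

In this assay the exchange at this place, on an aromatic carbon para to a large group, gives a 2.3-fold lower number from compound 3 to compound 4 (0.36 log units; beyond the scatter) and so separates dimethylamino from chloro. Dimethylamino in place of hydrogen gives a 1.2-fold higher number from compound 2 to compound 4 (0.08 log units; within the scatter) while chloro in place of hydrogen gives a 2.7-fold higher number from compound 2 to compound 3 (0.43 log units; beyond the scatter) and thus, among these three groups, only chloro stands apart in this series. Methyl in place of hydrogen on the aromatic nitrogen, read with dimethylamino held constant, gives a 1.4-fold lower number from compound 1 to compound 4 (0.13 log units; within the scatter) and does not separate this pair.

Nothing available here bears on the reason for these differences. Going by these compounds, it remains open whether a methoxy group or a carboxylic acid at this place would stand apart from hydrogen, and whether the nitrogen methyl reads the same with chloro on the ring.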